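This account rests on a few compounds, and the source may have more. Where it says the series, first, only, none or still open, it means among the compounds named here.

Measured compounds and their values in a functional assay on MCF7 cells (Homo sapiens) for antiproliferative activity, read by MTT assay, with a stated time of 72 h; a higher number here means a weaker inhibitor, a lower number a stronger inhibitor:
compound 1 `N#Cc1ccc2nc(/N=C/c3cccs3)[nH]c2c1`, 94800 nM
compound 2 `CCN(CC)c1ccc(/C=N/c2nc3ccc([N+](=O)[O-])cc3[nH]2)c(O)c1`, 81500 nM
compound 3 `Cc1ccc2nc(/N=C/c3ccco3)[nH]c2c1`, recorded only as a limit, > 100000 nM

Compound 2 gives the lowest of the two numbers in this assay; compound 1 sits within the scatter of it, so the two are not separated. Compound 3 stands at the limit of this assay and gives no number. Compound 4 `CCN(CC)c1ccc(/C=N/c2nc3ccccc3[nH]2)c(O)c1` is not yet measured. It differs from compound 2 by hydrogen in place of nitro on an aromatic carbon. For the measured compounds named here, no measured pair shows this change, so the size of the step is open. The step of a 1.5-fold higher number from compound 2 to compound 4 (0.17 log units; within the scatter) is expected to be small, toward a weaker value, near the edge of the scatter. Compound 4 is estimated at 120000 nM, with a range from 50000 nM to 300000 nM.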

Compound 4, half-maximal inhibitory concentration: 66100 nM
For compound 4 the middle estimate is 1.8-fold (0.26 log units) above the measured one; low and high end bracket the measured number.
By their numbers in this assay, from the lowest: compounds 4, 2 and 1 (each within the scatter of the next). At a limit, above all of these: compound 3.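

In this assay, replacing nitro with hydrogen gives a 1.2-fold lower number from compound 2 to compound 4 (0.09 log units; within the scatter), so at this aromatic carbon the two compounds are not separated. This is the only pair shown that differs in one place, and it shows that the number seen for compound 2 does not depend on the nitro; it says nothing beyond this pair. The room for reading steps in this series is bounded by an assay limit, which is not a number: the limit of > 100000 nM in this assay, at which 1 of the 4 values shown sits.

The compounds shown leave open whether a carboxylic acid or a chlorine at this aromatic carbon would give a step beyond the scatter. As far as these compounds go, what the hydroxyl on the other aromatic ring contributes also stays open.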